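The compounds below may be only part of what the source reports. "The series", "measured", "known", "first", "only" and "open" are said of these compounds alone.

In an ADME assay on Vero cells (Chlorocebus sabaeus) for cytotoxicity, read by MTT assay, with a stated time of 48 h (a lower number here means a stronger inhibitor, a higher number a weaker inhibitor), compound 1 `CC(=O)NC1CCC(CN2CCN(c3cc(=O)c4cc(C(F)(F)F)cc([N+](=O)[O-])c4s3)CC2)CC1` gives > 64 ug/mL, which is a limit of the assay rather than a number. Compound 2 `COc1ccc(C(=O)OC2CCC(CN3CCN(c4cc(=O)c5cc(C(F)(F)F)cc([N+](=O)[O-])c5s4)CC3)CC2)cc1` likewise gives > 64 ug/mL, again a limit. Compound 3 `O=c1cc(N2CCN(CC3CCC(OS(=O)(=O)c4ccc5ccccc5c4)CC3)CC2)sc2c([N+](=O)[O-])cc(C(F)(F)F)cc12` gives > 64 ug/mL, also a limit. Compound 2 therefore stands at the limit shared by all three values (the limit of > 64 ug/mL in this assay, at which 3 of the 3 values shown sit). Going by the values given here, the one measured step, a step that the two limits leave unreadable from compound 1 to compound 2, runs between two limits and its size cannot be read. Compound 4 `COc1cccc(C(=O)OC2CCC(CN3CCN(c4cc(=O)c5cc(C(F)(F)F)cc([N+](=O)[O-])c5s4)CC3)CC2)c1` differs from compound 2 by 3-methoxyphenyl in place of 4-methoxyphenyl on a carbonyl carbon. Among the compounds with values here, no measured step informs this change, and with every value at the limit no step beyond the scatter is expected in this assay in either direction. Compound 4 is therefore expected to give 100 ug/mL (range 64 ug/mL to 200 ug/mL), an expected step that the limit leaves unreadable from compound 2 to compound 4.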

Compound 4, half-maximal inhibitory concentration: > 64 ug/mL
Compound 4: only a limit was reported; the forecaster's own chance of this, stated with the estimate: 85%; the middle value does not contradict the limit.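

Going by these compounds alone, no step from compound 1 or compound 2 to compound 4 can be read, because all these values are limits: the limit of > 64 ug/mL in this assay, at which 4 of the 4 values shown sit. The compounds shown leave open what separates 3-methoxyphenyl from 4-methoxyphenyl, or either from acetamido, in size.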